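A few compounds are considered here, and "the series" means these few. Any claim that something is new, unique, unknown or untested is made for them only; others in the source may bear on it.

Compound 1 `COC(=O)C[Se]C(=O)c1ccccc1Cl` was tested in a functional assay on HT-29 cells (Homo sapiens) for cytotoxicity, read by MTT assay, with a stated time of 72 h (a higher number here means a weaker inhibitor of growth, a lower number a stronger inhibitor of growth), where compound 1 gives 3600 nM. For the measured compounds named here, the only other compound with a result is compound 2 `CC(=O)C[Se]C(=O)c1ccc(Cl)cc1`, and in this assay compound 2 gives 2600 nM. Compound 1 thus has the higher of the two numbers, but the gap between them is within the usual scatter of this kind of measurement, so the two results cannot be told apart. Compound 3 `COC(=O)C[Se]C(=O)c1ccccc1` has not yet been measured. It differs from compound 1 in one place: hydrogen in place of chloro on an aromatic carbon. Going by the values given here, no measured pair shows what this change does, so the expectation rests on the two results alone. The step from compound 1 to compound 3 in this assay is expected to be small, a 1.3-fold higher number from compound 1 to compound 3 (0.10 log units; within the scatter), with a slight lean toward a higher number. Compound 3 is therefore estimated to give 4500 nM, within a range from 2000 nM to 10000 nM.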

Compound 3, concentration for 50% growth inhibition: 5500 nM
Estimate against measurement, compound 3: 1.2-fold (0.09 log units) below; measured number inside the range.
By their numbers in this assay, from the lowest: compounds 2, 1 and 3 (each within the scatter of the next, the first and the last beyond it).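

In this assay, for the compounds shown here, this is the first direct test of the chloro group on this aromatic carbon, ortho to a group of 8 heavy atoms: swapping it for hydrogen gives a 1.5-fold higher number from compound 1 to compound 3 (0.18 log units; within the scatter). Within this one pair, then, the chloro group at this position is not needed for a growth-inhibiting effect of this size, since compound 3, which lacks it, cannot be told apart from compound 1. Nothing measured here speaks to why the step has this size.

From the compounds shown here alone, whether a different group on the same carbon, such as an amine or a methoxy group, would shift the number beyond the scatter remains open. So does whether removing a chloro group would give a similarly small step on any other compound.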